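The source may hold more compounds than are shown below. What is called first, only, known or untested is meant among the compounds shown, and "the series" means these compounds.

Measured so far in a functional assay on HL-60 cells (Homo sapiens) for cytotoxicity, read by luminescence and CellTiter-Glo, with a stated time of 3 days; a higher number here means a weaker inhibitor, a lower number a stronger inhibitor:
compound 1 `O=C(Nc1cc(C(F)(F)F)cc(C(F)(F)F)c1)c1cc(Cl)c(F)cc1O`: 430 nM
compound 2 `O=C(Nc1ccc(OC(F)(F)F)c(Cl)c1)c1cc(F)ccc1O`: 550 nM
compound 3 `Cc1cccc(O)c1C(=O)Nc1ccc(C#N)cc1`: 6860 nM

Compound 3 has the highest number of the three, which makes it the weakest inhibitor in this small set. The gaps from it down to compound 2 and to compound 1 both lie beyond the scatter.

The next compound is compound 4 `COc1cccc(O)c1C(=O)Nc1ccc(C#N)cc1`, which has methoxy in place of methyl on an aromatic carbon. The change sits ortho to a large group and meta to a hydroxy group.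

For the measured compounds named here, no two measured compounds differ in one place only, so the data give no direct size for this change. With nothing to suggest a direction, the expectation in this assay is no step beyond the scatter, starting from compound 3 at 6860 nM. The estimated step is a 1.1-fold lower number from compound 3 to compound 4 (0.06 log units; within the scatter). For compound 4 the expected value is 6000 nM, with an estimated range of 2000 nM to 18000 nM.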

Compound 4, half-maximal inhibitory concentration: > 10000 nM
Compound 4 gave a limit, no number (the forecaster's own chance of this, stated with the estimate: 10%); middle value at least 1.6-fold (0.22 log units) from the limit.
By their numbers in this assay, from the lowest: compounds 1 and 2 (each within the scatter of the next); then compound 3. At a limit, above all of these: compound 4.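

In this assay, for the compounds shown here, this pair gives the first direct reading of a single change on the shared core: methoxy in place of methyl, ortho to a large group and meta to a hydroxy group, comes with an at least 1.4-fold higher number from compound 3 to compound 4 (0.16 log units; that floor lies within the scatter). Compound 4 gives > 10000 nM, which is a limit of the assay and not a number. The step is thus only a floor: methoxy brings no lower number at this position, and the full size of the change cannot be read at the limit: the limit of > 10000 nM in this assay, at which 1 of the 4 values shown sits.

From the compounds shown here alone, whether an amine, an ethyl group or a chlorine at this position would give a measurable number remains open. Also open, going by these compounds, is whether methoxy in place of methyl would have the same outcome with the amide partners of compound 1 and compound 2.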